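Amide to Sulfonamide on the Shared Core

The source may report more compounds than this note shows. Statements on the series, on what has been measured and on what is new or still open speak of the compounds shown alone.

Among the compounds with values here, compound 2 `COC(=O)/C=C/C(=O)N[C@@H](C)Cn1ccc(-c2ccc(C#N)c(Cl)c2)n1` gives 2460 nM in a functional assay on LNCaP cells (Homo sapiens) for antiproliferative activity, read by CCK-8 assay, with a stated time of 6 days (a higher number here means a weaker inhibitor, a lower number a stronger inhibitor), the lower of the two numbers measured so far; its nearest neighbour, compound 1 `CC(O)c1ccc(C(=O)N[C@@H](C)Cn2ccc(-c3ccc(C#N)c(Cl)c3)n2)cc1`, gives 3690 nM, and the step of a 1.5-fold lower number from compound 1 to compound 2 (0.18 log units; within the scatter) stays within the scatter. Compound 3 `C[C@@H](Cn1ccc(-c2ccc(C#N)c(Cl)c2)n1)NS(=O)(=O)c1cn(C)cn1` has not yet been measured. It differs from compound 2 in one place: (1-methyl-1H-imidazol-4-yl)sulfonyl in place of (2-(methoxycarbonyl)ethenyl)carbonyl on an amine nitrogen. Within the data shown here, no measured step bears directly on this exchange; the only step seen, a 1.5-fold lower number from compound 1 to compound 2 (0.18 log units; within the scatter), swapped one carbonyl substituent for another and left the number essentially unchanged, and the replacement of the carbonyl itself by a sulfonyl group has no precedent among the measured compounds. On that basis the author expects no step beyond the scatter, a 1.0-fold higher number from compound 2 to compound 3 (0.01 log units; within the scatter), while allowing wide room either way. Compound 3 is therefore estimated to give 2500 nM in this assay, within a range from 800 nM to 8000 nM.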

Compound 3, half-maximal inhibitory concentration: > 30000 nM
Compound 3: a limit, no number; the forecaster's own chance of this, stated with the estimate: 10%; at least 12-fold (1.07 log units) between middle value and limit.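

Within the data shown here, until now, the only change at the amine nitrogen had swapped one carbonyl substituent for another, and that step stayed within the scatter. Here the change goes beyond the carbonyl substituent: (1-methyl-1H-imidazol-4-yl)sulfonyl in place of (2-(methoxycarbonyl)ethenyl)carbonyl in this assay gives an at least 12-fold higher number from compound 2 to compound 3 (1.08 log units; beyond the scatter), so this position does not accept every acylating group alike. Compound 3 carries a limit of the assay, not a number: the limit of > 30000 nM in this assay, at which 1 of the 3 values shown sits.

The compounds shown leave open whether the loss follows the sulfonyl link or the 1-methyl-1H-imidazol-4-yl ring, as the two entered together. A phenyl or methyl group on the sulfonyl, or the 1-methyl-1H-imidazol-4-yl ring on a carbonyl, would separate the two.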